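From 2-(pyridin-2-yl)ethenyl to 4-phenylphenyl

This account rests on a few compounds, and the source may have more. Where it says the series, first, only, none or still open, it means among the compounds named here.

- compound 1 `Cn1cncc1C(OCc1ccc(C#N)cc1-c1ccccc1)c1ccc(C#N)cc1` gives 140 nM
- compound 2 `CCC/C=C/C=C/c1cc(C#N)ccc1COC(c1ccc(C#N)cc1)c1cncn1C` gives 16.7 nM
- compound 3 `Cn1cncc1C(OCc1ccc(C#N)cc1/C=C/c1ccccn1)c1ccc(C#N)cc1` gives 23.1 nM
- compound 4 `Cn1cncc1C(OCc1ccc(C#N)cc1-c1ccc(-c2ccccc2)cc1)c1ccc(C#N)cc1` is not yet measured

In a functional assay on NIH3T3 cells (Mus musculus) (a lower number here means that less compound is needed, a higher number that more compound is needed for the effect), compound 3 stands level with compound 2, with a 1.4-fold higher number from compound 2 to compound 3 (0.14 log units; within the scatter), and well under compound 1. The next change is 4-phenylphenyl in place of 2-(pyridin-2-yl)ethenyl on an aromatic carbon. For the measured compounds named here, two measured steps bear on it, an 8.4-fold lower number from compound 1 to compound 2 (0.92 log units; beyond the scatter) and a 6.1-fold lower number from compound 1 to compound 3 (0.78 log units; beyond the scatter), and both replace the phenyl of compound 1. Going by the values given here, the group in compound 4 still carries a phenyl on that carbon's substituent, so only part of that gain is expected to survive, though no measured step tests this. The expected move is a 2.6-fold higher number from compound 3 to compound 4 (0.41 log units; beyond the scatter), towards a higher number. For compound 4 the estimated value is 60 nM, within a range of 15 nM to 240 nM.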

Compound 4, half-maximal effective concentration: < 0.1 nM
Compound 4 gave a limit, no number; the forecaster's own chance of this, stated with the estimate: 3%; at least 600-fold (2.77 log units) between middle value and limit.
By their numbers in this assay, from the lowest: compounds 2 and 3 (each within the scatter of the next); then compound 1. At a limit, below all of these: compound 4.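

In this assay, the group on this aromatic carbon turns out to matter far more than the earlier, modest steps suggested: a phenyl in place of hydrogen on the phenyl of compound 1 gives an at least 1400-fold lower number from compound 1 to compound 4 (3.14 log units; beyond the scatter). The 4-phenylphenyl group also outdoes both chain-linked groups, with an at least 230-fold lower number from compound 3 to compound 4 (2.36 log units; beyond the scatter) and an at least 160-fold lower number from compound 2 to compound 4 (2.22 log units; beyond the scatter). Compound 4 stands at a limit of the assay, not at a number, so these steps give only minimum sizes: the limit of < 0.1 nM in this assay, at which 1 of the 4 values shown sits.

Going by these compounds, the true value of compound 4 remains open. So does whether a methoxy group, an amine or a carboxylic acid in place of the outer phenyl would hold this gain.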